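Ester in place of amide: expected cytotoxicity of compound 4

The compounds below may be only part of what the source reports. "The series", "measured", "known", "first", "only" and "open" are said of these compounds alone.

Three compounds have been measured in an ADME assay on TZM cells (Homo sapiens) for cytotoxicity, read by XTT assay, with a stated time of 4 days; a lower number here means that less compound is tolerated, a higher number that more compound is tolerated:
compound 1, `Cc1cc(CO)cc(C)c1Oc1cc(Nc2ccc(C#N)cc2)c(N)cc1CO`, gives 15900 nM;
compound 2, `Cc1cc(CCC#N)cc(C)c1Oc1cc(Nc2ccc(C#N)cc2)c(N)cc1C(N)=O`, gives > 9400 nM, which is a limit of the assay and not a number;
compound 3, `Cc1cc(/C=C/C#N)cc(C)c1Oc1cc(Nc2ccc(C#N)cc2)c(N)cc1C(N)=O`, gives > 23600 nM, also a limit of the assay and not a number.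

Compound 2 thus stands only at a limit in this assay, and one further value shown, that of compound 3, is likewise a limit. Among the compounds with values here, the single step between compounds differing in one place, a step that the two limits leave unreadable from compound 2 to compound 3, therefore has no readable size. Compound 1 differs from compound 2 in more than one place, so its value is not a step.

Compound 4, `COC(=O)c1cc(N)c(Nc2ccc(C#N)cc2)cc1Oc1c(C)cc(CCC#N)cc1C`, differs from compound 2 as follows: methoxy in place of amino on a carbonyl carbon. Within the data shown here, no measured step touches the carbonyl carbon or the carbamoyl group, so no measured step bears on this change, and no size in either direction can be read from the data. Within that silence, no step beyond the usual scatter is expected. The step from compound 2 to compound 4 is expected to be a step that the limit leaves unreadable from compound 2 to compound 4. Compound 4 is estimated at 20000 nM, with a range from 8000 nM to 50000 nM.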

Compound 4, half-maximal cytotoxic concentration in the TZM assay: > 22700 nM
Compound 4: no number, only a limit; the forecaster's own chance of this, stated with the estimate: 60%; middle value at least 1.1-fold (0.05 log units) from the limit.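

Compound 2 and compound 4 both stand at limits of the TZM assay and not at numbers, so no step can be read between them. In a physicochemical assay for solubility, with a stated time of 4 h, at pH 2.0 (a lower number here means a less soluble compound, a higher number a more soluble compound), compound 2 gives 9.11 ug/mL and compound 4 gives 21.8 ug/mL, which is a 2.4-fold higher number from compound 2 to compound 4 (0.38 log units; beyond the scatter). The compounds shown leave open whether methoxy in place of amino on a carbonyl carbon changes the half-maximal cytotoxic concentration at all.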